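Swapping the Bicyclic Head Group of a Potent Inhibitor

The source may hold more compounds than are shown below. What is called first, only, known or untested is meant among the compounds shown, and "the series" means these compounds.

Three amides sharing one core have been measured in an assay for inhibition of Nicotinamide phosphoribosyltransferase (Homo sapiens), read by mass spectrometry, with stated times of 15 min and 30 min; on this read-out lower numbers stand for stronger inhibition and higher numbers for weaker inhibition. Compound 1 `O=C(NCc1ccc(S(=O)(=O)N2CCCCC2)cc1)c1cc2cnccc2s1` gives 150 nM, and compound 2 `O=C(NCc1ccc(S(=O)(=O)N2CCCCC2)cc1)c1cc2cnccc2o1` gives 140 nM; the step of a 1.1-fold lower number from compound 1 to compound 2 (0.03 log units; within the scatter) shows that trading the sulfur-containing bicycle for its oxygen counterpart changes nothing that can be trusted. Compound 3 `O=C(NCc1ccc(S(=O)(=O)N2CCCCC2)cc1)c1cnc2nccn2c1` gives 3 nM, the lowest number of the three, and its steps to the others, a 50-fold lower number from compound 1 to compound 3 (1.70 log units; beyond the scatter) and a 47-fold lower number from compound 2 to compound 3 (1.67 log units; beyond the scatter), both lie well beyond the scatter, so compound 3 is the strongest inhibitor seen so far.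

Compound 4 `O=C(NCc1ccc(S(=O)(=O)N2CCCCC2)cc1)c1ccc2nc[nH]c2c1` again alters only the head group on the carbonyl carbon: a group of 9 heavy atoms (7 carbon, 2 nitrogen; one five-membered aromatic ring with 2 hetero atoms, one six-membered aromatic ring of carbon only) in place of a group of 9 heavy atoms (6 carbon, 3 nitrogen; one five-membered aromatic ring with 2 hetero atoms, one six-membered aromatic ring with 2 hetero atoms), on a carbonyl carbon. The two large steps into compound 3 show that this position governs potency strongly, while the step from compound 1 to compound 2 shows that not every swap there matters. For the measured compounds named here, no measured pair contains a benzimidazole, so the direction rests on the earlier swaps alone. The step from compound 3 to compound 4 is expected to raise the number, roughly a 27-fold higher number from compound 3 to compound 4 (1.43 log units; beyond the scatter), because compound 3, at 3 nM, sits far below the other two and any departure from its head group seems more likely to lose than to gain. Compound 4 is therefore estimated at 80 nM, within a range from 10 nM to 600 nM.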

Compound 4, half-maximal inhibitory concentration: 310 nM
Compound 4: middle estimate off by 3.9-fold (0.59 log units), on the low side, within the range that was stated.
By their numbers in this assay, from the lowest: compound 3; then compounds 2 and 1 (each within the scatter of the next); then compound 4.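

In this assay the step of a 100-fold higher number from compound 3 to compound 4 (2.01 log units; beyond the scatter) shows that a head group with the same count of heavy atoms, and also built from a five-membered and a six-membered aromatic ring, can lose nearly all the potency of the best one. Matching size and ring sizes is therefore not enough at this carbonyl carbon. The steps of a 2.2-fold higher number from compound 2 to compound 4 (0.35 log units; beyond the scatter) and a 2.1-fold higher number from compound 1 to compound 4 (0.32 log units; beyond the scatter) are modest but beyond the scatter and leave compound 4 the weakest of the four, while only compound 3 reaches the low end of the range.

Going by these compounds, whether the loss goes with the added hydrogen-bond donor or with the all-carbon six-membered ring stays open, as does what a single pyridine ring would give on the same carbonyl carbon. No measurement shown here explains these differences.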